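The compounds below may be only part of what the source reports. "The series", "measured", "known", "first", "only" and "open" are said of these compounds alone.

Three compounds here share one core and differ only in the group carried on the five-membered ring. Compound 1 `CCCCCCCCc1ccc(OCC(=O)Cn2nnc(-c3ccccc3)n2)cc1` gives 24 nM in an assay on microsomes from brain for inhibition of Fatty-acid amide hydrolase 1 (Rattus norvegicus), read by fluorescence and HPLC, with a stated time of 60 min; a lower number here means a stronger inhibitor, a higher number a weaker inhibitor. Compound 2 `CCCCCCCCc1ccc(OCC(=O)Cn2nnc(-c3cccc(Cl)c3)n2)cc1` gives 24 nM in this assay, and compound 3 `CCCCCCCCc1ccc(OCC(=O)Cn2nnc(-c3ccc(C(=O)OC)cc3)n2)cc1` gives 29 nM in this assay. Compound 3 holds the highest of the three numbers, yet both of its neighbours sit within the scatter of it: the gap to compound 1 and the gap to compound 2 are each too small to count as a difference. The measured steps say the same, with no change at the digits printed from compound 1 to compound 2 (within the scatter), a 1.2-fold higher number from compound 1 to compound 3 (0.08 log units; within the scatter) and a 1.2-fold higher number from compound 2 to compound 3 (0.08 log units; within the scatter).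

Compound 4 `CCCCCCCCc1ccc(OCC(=O)Cn2nnc(Cc3ccccc3)n2)cc1` is not yet measured. Its change from compound 3 is benzyl in place of 4-(methoxycarbonyl)phenyl on an aromatic carbon. For the measured compounds named here, the steps that bear on it are those that altered the aryl group, above all the exchange of one whole aryl group for another from compound 2 to compound 3, and every one of them stayed within the scatter. Going by the values given here, no measured step, however, replaces an aryl group by a benzyl group, so that part of the change is untested. On the evidence of the three measured compounds no step beyond the scatter is expected in this assay, with a slight lean toward a higher number. Compound 4 is therefore estimated at 40 nM, with a range from 12 nM to 130 nM, which corresponds to an expected 1.4-fold higher number from compound 3 to compound 4 (0.14 log units; within the scatter).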

Compound 4, half-maximal inhibitory concentration: 66 nM
Compound 4: middle estimate off by 1.7-fold (0.22 log units), on the low side; low and high end bracket the measured number.
By their numbers in this assay, from the lowest: compounds 1, 2 and 3 (each within the scatter of the next); then compound 4.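

Benzyl is the first group at this place, on the aromatic carbon of the five-membered ring, to move the number in this assay beyond the scatter, giving a 2.3-fold higher number from compound 3 to compound 4 (0.36 log units; beyond the scatter) and, from the other two aryl compounds, a 2.8-fold higher number from compound 2 to compound 4 (0.44 log units; beyond the scatter) and a 2.8-fold higher number from compound 1 to compound 4 (0.44 log units; beyond the scatter). The rise appears from plain phenyl as well as from the two substituted phenyl groups, so it is not tied to the loss of the methoxycarbonyl or the chloro group; among these four compounds, the three with the aromatic ring set directly on this carbon stand within the scatter of each other, and compound 4, with the ring held through the extra carbon of benzyl, is the one that departs, though only modestly. No measurement here explains why this change raises the number.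

The compounds shown leave open whether a longer link, as in 2-phenylethyl, would raise the number further, and whether a chloro or methoxycarbonyl group on the benzyl ring would bring it back. They also do not show how this place responds to a group with no aromatic ring at all, such as a simple methyl, an amine or a carboxylic acid.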